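The compounds below may be only part of what the source reports. "The series", "measured", "known", "first", "only" and "open" are said of these compounds alone.

In a functional assay on NCI-H460 cells (Homo sapiens) for antiproliferative activity, read by MTT assay, with a stated time of 72 h (a lower number here means a stronger inhibitor, a higher number a weaker inhibitor), compound 3 `Cn1ccc2c(Oc3ccc(NC(=O)c4cc5cccnc5n(-c5ccc(F)cc5)c4=O)cc3F)ccnc21` gives 250 nM; it is one of two compounds for which a number has been reported. Compound 1 `O=C(Nc1ccc(Oc2ccnc3[nH]ccc23)c(F)c1)c1cc2cccnc2n(-c2ccc(Br)cc2)c1=O` carries a bromophenyl group and lacks the methyl group on the bicyclic ring of compound 3. In this assay compound 1 gives 260 nM, which lies within the scatter of the value of compound 3, so nothing separates the two. Compound 2 `Cn1ccc2c(Oc3ccc(NC(=O)c4cc5cccnc5n(-c5ccc(Br)cc5)c4=O)cc3)ccnc21` in this assay is reported as "not determined" (no result reported).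

Compound 4 `Cn1ccc2c(Oc3ccc(NC(=O)c4cc5cccnc5n(-c5ccc(Br)cc5)c4=O)cc3F)ccnc21` has not yet been measured. It differs from compound 3 by bromo in place of fluoro on an aromatic carbon, the same difference that, cut one bond further out, reads 4-fluorophenyl to 4-bromophenyl. Within the data shown here, no pair of measured compounds isolates this change, so no step size can be read from the data. The author expects a step of a 1.1-fold lower number from compound 3 to compound 4 (0.04 log units; within the scatter), that is, nothing beyond the scatter, and for compound 4 in this assay estimates 230 nM, with a range from 100 nM to 520 nM.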

Compound 4, half-maximal inhibitory concentration: 420 nM
Estimate against measurement, compound 4: 1.8-fold (0.26 log units) below, and the stated range covers the measured number.
By their numbers in this assay, from the lowest: compounds 3, 1 and 4 (each within the scatter of the next).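

Compound 4 links two measured neighbours in this assay, so that two single changes can be read directly. Bromo in place of fluoro on the aromatic carbon para to a large group is a 1.7-fold higher number from compound 3 to compound 4 (0.23 log units; within the scatter), and methyl in place of hydrogen on an aromatic nitrogen is a 1.6-fold higher number from compound 1 to compound 4 (0.21 log units; within the scatter), so neither change separates the compounds beyond the usual scatter. No measurement shown offers a reason for either step.

The compounds shown leave open whether a group other than a halogen at this position of the phenyl ring, such as an amine or a carboxylic acid, would move the number beyond the scatter. As far as these compounds go, whether a longer chain in place of the methyl on the aromatic nitrogen would do so also remains open.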